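Adding a second chloro to the anilide ring of a sulfonyl-hydroxyguanidine

This account rests on a few compounds, and the source may have more. Where it says the series, first, only, none or still open, it means among the compounds named here.

Three sulfonyl-hydroxyguanidines have been measured in a functional assay on KB cells (Homo sapiens) for cytotoxicity; a lower number here means a stronger inhibitor, a higher number a weaker inhibitor. Compound 1 `Cc1ccc(S(=O)(=O)N/C(=N\O)Nc2ccc(Cl)cc2)cc1` gives 46 ug/mL, and compound 3 `Cc1ccc(S(=O)(=O)N/C(=N\O)Nc2ccc(Cl)c(Cl)c2)cc1` gives 8 ug/mL. Compound 3 differs from compound 1 by chloro in place of hydrogen on an aromatic carbon, and that change made a 5.8-fold lower number from compound 1 to compound 3 (0.76 log units; beyond the scatter). Compound 2 `Cc1c(S(=O)(=O)N/C(=N\O)Nc2ccc(Cl)cc2)sc2ccc(Cl)cc12` carries a different core; the difference between the two cores is not broken down here. In this assay compound 2 gives 29 ug/mL. Compound 4 `Cc1c(S(=O)(=O)N/C(=N\O)Nc2ccc(Cl)c(Cl)c2)sc2ccc(Cl)cc12`, not yet measured, differs from compound 2 by chloro in place of hydrogen on an aromatic carbon, the same change that turned compound 1 into compound 3. Because compound 1 to compound 3 gave a 5.8-fold lower number from compound 1 to compound 3 (0.76 log units; beyond the scatter), a step of similar size is expected from compound 2 to compound 4, namely a 5.8-fold lower number from compound 2 to compound 4 (0.76 log units; beyond the scatter). Compound 4 is therefore estimated at 5 ug/mL, between 2.5 ug/mL and 12 ug/mL.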

Compound 4, half-maximal inhibitory concentration: > 300 ug/mL
Compound 4 gave a limit, no number (the forecaster's own chance of this, stated with the estimate: 5%); at least 60-fold (1.77 log units) between middle value and limit.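

In this assay compound 4 gives > 300 ug/mL, which is a limit of the assay and not a number. On this core the added chloro brought an at least 10-fold higher number from compound 2 to compound 4 (1.01 log units; beyond the scatter), so the change did not carry over from the core of compound 1, and the direction of the step reversed: the same change on two cores in this assay, a 5.8-fold lower number (0.76 log units; beyond the scatter) from compound 1 to compound 3 and an at least 10-fold higher number (1.01 log units; beyond the scatter) from compound 2 to compound 4, at least 59-fold (1.77 log units) apart, beyond the scatter of two such steps This rests on one pair per core, so it does not show which difference between the cores matters, and the full size of the step stays unknown: the limit of > 300 ug/mL in this assay, at which 1 of the 4 values shown sits.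

As far as these compounds go, it remains open how a fluoro or a methoxy group in place of the added chloro would behave on each core. Which part of the two cores separates the two outcomes also remains open.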